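The source may hold more compounds than are shown below. What is called first, only, known or untested is meant among the compounds shown, and "the series" means these compounds.

Working notes on the series, read in an ADME assay on Vero 76 cells (Chlorocebus sabaeus) for cytotoxicity, read by MTT assay, with a stated time of 96 h; a lower number here means that less compound is tolerated, a higher number that more compound is tolerated. Compound 2 `NS(=O)(=O)c1ccc(N2N=C(c3ccc(OCc4ccccc4)cc3)CC2c2ccc(Cl)cc2)cc1` gives 82000 nM. Compound 1 `Cc1ccccc1C1CC(c2ccc(OCc3ccccc3)cc2)=NN1c1ccc(S(N)(=O)=O)cc1` gives 100000 nM, within the scatter of compound 2, so no order is drawn between the two. Compound 3 `NS(=O)(=O)c1ccc(N2N=C(c3ccc(Oc4ccccc4)cc3)CC2c2ccccc2Cl)cc1` gives 29000 nM, a lower number than either and beyond the scatter of compound 2. Compound 2 therefore stands with compound 1 as the upper pair of the three numbers.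

Compound 4 `Cc1cccc(C2CC(c3ccc(OCc4ccccc4)cc3)=NN2c2ccc(S(N)(=O)=O)cc2)c1` has not yet been measured. It departs from compound 2 in one place: 3-methylphenyl in place of 4-chlorophenyl on a saturated ring carbon. In words, 3-methylphenyl stands in place of 4-chlorophenyl on a saturated ring carbon.

The measured step that bears on this is a 1.2-fold lower number from compound 1 to compound 2 (0.09 log units; within the scatter). Among the compounds with values here, it concerns the same ring carbon and the same 4-chlorophenyl group, but with 2-methylphenyl as the partner, and 3-methylphenyl itself has no measured precedent. Within the data shown here, compound 3 differs from compound 2 in more than one place, so it offers no clean step here.

No change beyond the scatter is expected in this assay, and the estimated step is a 1.0-fold lower number from compound 2 to compound 4 (0.01 log units; within the scatter). For compound 4 the estimate is 80000 nM, with an expected range of 40000 nM to 100000 nM.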

Compound 4, half-maximal cytotoxic concentration: 100000 nM
Estimate against measurement, compound 4: 1.3-fold (0.10 log units) below, within the range that was stated.
By their numbers in this assay, from the lowest: compound 3; then compounds 2, 1 and 4 (each within the scatter of the next).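

In this assay, 3-methylphenyl in place of 4-chlorophenyl on the saturated ring carbon gives a 1.2-fold higher number from compound 2 to compound 4 (0.09 log units; within the scatter), so this exchange of one substituted phenyl group for another leaves the number within the scatter. Within the data shown here, the result also adds a comparison the earlier compounds could not give, between two placements of the methyl on the phenyl group: 3-methylphenyl in place of 2-methylphenyl gives no change at the digits printed from compound 1 to compound 4 (within the scatter), so the two methylphenyl groups are not separated at this position. With 2-methylphenyl, 3-methylphenyl and 4-chlorophenyl all within the scatter here, this position tolerates these three groups alike in this assay, though nothing available bears on why these exchanges leave the number in place.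

On these data alone, all three groups are substituted phenyl rings, so what an amine, a carboxylic acid or a longer alkyl chain on this saturated ring carbon would do to the number remains open. Compound 3 differs from these compounds in more than one place, so its lower number cannot be tied to any single change, and the separate contributions of its 2-chlorophenyl and phenoxy groups remain unresolved.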